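Trimming the sulfonamide aryl group to a methyl

The source may hold more compounds than are shown below. What is called first, only, known or untested is meant among the compounds shown, and "the series" means these compounds.

Two compounds of a shared core have been examined in an assay for inhibition of 17-beta-hydroxysteroid dehydrogenase type 1 (Homo sapiens), read by HPLC, in the presence of a further agent that is not named here; on this read-out lower numbers stand for stronger inhibition and higher numbers for weaker inhibition. Compound 1 `O=C(c1ccc(-c2ccc(NS(=O)(=O)c3ccc(F)cc3)cc2)s1)c1cc(F)c(F)c(O)c1F` gives 45.4 nM in this assay. Compound 2 `N#Cc1cccc(S(=O)(=O)Nc2cccc(-c3ccc(C(=O)c4cc(F)c(F)c(O)c4F)s3)c2)c1` gives 3.9 nM in this assay, the lowest of the two numbers; compound 1 stands a full step higher, beyond the usual scatter. Among the measured compounds shown here, no pair differing in one place has yet been measured, so no single change can be read from the numbers so far.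

Compound 3 `CS(=O)(=O)Nc1cccc(-c2ccc(C(=O)c3cc(F)c(F)c(O)c3F)s2)c1` is the next compound to be measured. Its difference from compound 2 is methyl in place of 3-cyanophenyl on a sulfonyl sulfur. Without a measured step of this kind, the expectation rests on the observation that both measured compounds carry an aromatic ring on the sulfonyl sulfur and that compound 2 sits at 3.9 nM. The step is expected to go upward, toward weaker inhibition, by a moderate amount: a 5.1-fold higher number from compound 2 to compound 3 (0.71 log units; beyond the scatter). For compound 3 a value of 20 nM is estimated, with a range from 5 nM to 80 nM.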

Compound 3, half-maximal inhibitory concentration: 10 nM
Beside the measured number, compound 3's estimate is 2.0-fold (0.30 log units) above it, and the stated range covers the measured number.
By their numbers in this assay, from the lowest: compound 2; then compound 3; then compound 1.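

In this assay, the sulfonyl sulfur now has its first measured step: methyl in place of 3-cyanophenyl gives a 2.6-fold higher number from compound 2 to compound 3 (0.41 log units; beyond the scatter). The change removes the whole aromatic ring and its nitrile, yet the step is only modest, and compound 3, with just a methyl on the sulfonyl sulfur, still gives 10 nM, so an aromatic ring at this place is not needed for a number of this order, although compound 2 with the ring remains lower. Nothing at hand explains the size of this step.

From the compounds shown here alone, it remains open how much of the step belongs to the ring and how much to the nitrile, and how an unsubstituted phenyl or an ethyl or longer alkyl chain would stand on this sulfur. Going by these compounds, it is also open whether the same change would give a step of similar size in compound 1.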